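The source may hold more compounds than are shown below. What is called first, only, known or untested is meant among the compounds shown, and "the series" means these compounds.

Compound 2 `CCOC(=O)c1oc2ccc(N(Cc3ccccc3)S(=O)(=O)c3ccccc3Br)cc2c1C` and compound 1 `CCOC(=O)c1oc2ccc(N(Cc3ccccc3)S(=O)(=O)c3ccc(Br)cc3)cc2c1C` share one core and differ only in the ring on the sulfonyl sulfur. In a functional assay on HCT-116 cells (Homo sapiens) for inhibition, read by MTT assay, with a stated time of 72 h (on this read-out higher numbers stand for weaker inhibition and lower numbers for stronger inhibition), compound 1 gives 8700 nM. In this assay compound 2 gives > 40000 nM, which is a limit of the assay and not a number. So compound 2 stands at the weak end of the values shown, and the step of an at least 4.5-fold higher number from compound 1 to compound 2 (0.66 log units; beyond the scatter) is the only measured step, with its true size unknown because of the limit of > 40000 nM in this assay, at which 1 of the 2 values shown sits.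

Compound 3 `CCOC(=O)c1oc2ccc(N(Cc3ccccc3)S(=O)(=O)c3ccc(C)cc3)cc2c1C` is not yet measured. Against compound 2 it shows (4-methylphenyl in place of 2-bromophenyl on a sulfonyl sulfur). Among the compounds with values here, the one measured step bears on this change only loosely: it tells that swapping 4-bromophenyl for 2-bromophenyl on the sulfonyl sulfur weakens inhibition by at least a modest amount, and compound 3 carries a 4-methylphenyl there instead. It is therefore expected that compound 3 gives a stronger number than compound 2, of roughly an at least 3.3-fold lower number from compound 2 to compound 3 (0.52 log units; beyond the scatter). The estimate for compound 3 in this assay is 12000 nM, between 4000 nM and 40000 nM.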

Compound 3, half-maximal inhibitory concentration: > 40000 nM
Compound 3 ended at the assay's limit; the forecaster's own chance of this, stated with the estimate: 25%; middle value at least 3.3-fold (0.52 log units) away from the limit.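

Replacing bromo with methyl on an aromatic carbon of the ring on the sulfonyl sulfur weakens inhibition in this assay, and the change gives an at least 4.5-fold higher number from compound 1 to compound 3 (0.66 log units; beyond the scatter). The earlier compounds showed only that the bromine could not be exchanged for the 2-bromophenyl arrangement without a loss; this result shows that a 4-substituted ring does not by itself keep a readable value, since the 4-methylphenyl ring loses it too, so among these three compounds only the 4-bromophenyl ring of compound 1 gives a real number. The step between compound 2 and compound 3 cannot be read, and neither compound can be ranked against the other, because both values are limits of the assay and not numbers: the limit of > 40000 nM in this assay, at which 2 of the 3 values shown sit.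

From the compounds shown here alone, how far compound 2 and compound 3 actually lie from compound 1 therefore stays unknown. Also open, going by these compounds, is whether the effect belongs to bromine in particular, which a 4-chlorophenyl, 4-fluorophenyl or 4-methoxyphenyl ring on the sulfonyl sulfur could help to settle.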